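Swapping Chloro for Bromo on a Fused Aromatic Ring

The source may report more compounds than this note shows. Statements on the series, on what has been measured and on what is new or still open speak of the compounds shown alone.

Of the compounds shown here, three built on one shared core have been measured in an assay on a cell-free system (plasma) for inhibition of Dipeptidyl peptidase 4 (Rattus norvegicus), read by fluorescence; on this read-out lower numbers stand for stronger inhibition and higher numbers for weaker inhibition. Compound 1 `O=C([C@@H]1C[C@H](N2CCc3ccccc32)CN1)N1CCSC1` carries hydrogen on the aromatic carbon of interest, and in this assay compound 1 gives 19.5 nM. Compound 2 `O=C([C@@H]1C[C@H](N2CCc3cc([N+](=O)[O-])ccc32)CN1)N1CCSC1` carries a nitro group at that carbon; in this assay compound 2 gives 10.3 nM. Compound 3 `O=C([C@@H]1C[C@H](N2CCc3cc(Cl)ccc32)CN1)N1CCSC1` carries chloro there, and in this assay compound 3 gives 13.4 nM. On these numbers compound 3 lies between the other two, nearest to compound 2, and every step among the three stays within the scatter: a 1.9-fold lower number from compound 1 to compound 2 (0.28 log units; within the scatter) and a 1.5-fold lower number from compound 1 to compound 3 (0.16 log units; within the scatter).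

Compound 4 `O=C([C@@H]1C[C@H](N2CCc3cc(Br)ccc32)CN1)N1CCSC1` has not yet been measured. It differs from compound 3 in one place: bromo in place of chloro on an aromatic carbon. Within the data shown here, two measured steps bear on this spot, both ending at compound 3: a 1.5-fold lower number from compound 1 to compound 3 (0.16 log units; within the scatter) and a 1.3-fold higher number from compound 2 to compound 3 (0.11 log units; within the scatter). Hydrogen, nitro and chloro at this carbon all leave the number within the scatter of one another, so replacing chloro with bromo is expected to behave the same way, producing no step beyond the scatter. In this assay the expected step is a 1.1-fold lower number from compound 3 to compound 4 (0.05 log units; within the scatter). Compound 4 is therefore estimated at 12 nM, with a range from 6 nM to 25 nM.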

Compound 4, half-maximal inhibitory concentration: 10.7 nM
Compound 4: middle estimate off by 1.1-fold (0.05 log units), on the high side; measured number inside the range.
By their numbers in this assay, from the lowest: compounds 2, 4, 3 and 1 (each within the scatter of the next).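

Bromo adds a second halogen to the groups tested at this aromatic carbon, and in this assay replacing chloro with bromo gives a 1.3-fold lower number from compound 3 to compound 4 (0.10 log units; within the scatter) and so does not move the number beyond the scatter. Measured against the other two groups, the same bromo gives a 1.0-fold higher number from compound 2 to compound 4 (0.02 log units; within the scatter) when it replaces nitro and a 1.8-fold lower number from compound 1 to compound 4 (0.26 log units; within the scatter) when it replaces hydrogen, and neither of these steps leaves the scatter either. The flat picture at this carbon now covers four groups rather than three, hydrogen, nitro, chloro and bromo, though no measurement shown here explains why they read so alike.

The compounds shown leave open whether a different kind of group at this carbon, such as an amine, a carboxylic acid or a longer chain, would produce a step beyond the scatter. They also leave open how these same groups would behave on the other carbons of this six-membered aromatic ring.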